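Lengthening the acid chain on a shared core

The source may report more compounds than this note shows. Statements on the series, on what has been measured and on what is new or still open speak of the compounds shown alone.

Compound 1 `Nc1nc2[nH]c(CCCCCCCCC(=O)N[C@@H](CCC(=O)O)C(=O)O)cc2c(=O)[nH]1`: > 1000 nM
Compound 2 `Nc1nc2[nH]c(CCCCCC(=O)O)cc2c(=O)[nH]1`: > 1000 nM
Compound 3 `Nc1nc2[nH]c(CCCCCCCC(=O)O)cc2c(=O)[nH]1`: > 1000 nM

Among the measured compounds shown here, every value so far in a functional assay on PC43-10 cells (Cricetulus griseus) for inhibition, read by CellTiter-Blue, with a stated time of 96 h (a lower number here means a stronger inhibitor, a higher number a weaker inhibitor), is a limit of the assay rather than a number, as the limit of > 1000 nM in this assay, at which 3 of the 3 values shown sit, records. Compound 3 stands at that limit, with no number of its own. For the measured compounds named here, the only measured step that resembles the present change, a step that the two limits leave unreadable from compound 2 to compound 3, cannot be read for the same reason. Compound 4 `Nc1nc2[nH]c(CCCCCCCCC(=O)O)cc2c(=O)[nH]1` differs from compound 3 by carboxymethyl in place of carboxy on a saturated chain carbon, seven bonds along the chain from an aromatic carbon. No readable step bears on this change, so no direction can be expected beyond the scatter. Compound 4 is therefore estimated at 3000 nM, with a range from 1000 nM to 10000 nM, and most likely again only a limit. The expected step that the limit leaves unreadable from compound 3 to compound 4 is accordingly small.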

Compound 4, half-maximal inhibitory concentration: > 1000 nM
Compound 4 gave a limit, no number; the forecaster's own chance of this, stated with the estimate: 85%; the middle value does not contradict the limit.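

No step can be read among compound 1, compound 2, compound 3 and compound 4 in this assay, since each result is only a limit: the limit of > 1000 nM in this assay, at which 4 of the 4 values shown sit.

The compounds shown leave open whether any acid chain length on the shared core would give a number of its own.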